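The compounds below may be only part of what the source reports. "The series", "measured", "known", "first", "only" and "open" are said of these compounds alone.

Compound 2 `O=C(Nc1c(C(O)(C(F)(F)F)C(F)(F)F)ccc2ccccc12)c1ccccc1Cl` holds the highest of the two numbers measured in an assay on LtK cells with ATP-sensitive inward rectifier potassium channel 11 (Homo sapiens) as the target; on this read-out lower numbers stand for an effect already at smaller amounts and higher numbers for an effect only at larger amounts of compound: compound 2 gives 2040 nM, while compound 1 `CC(=O)Nc1c(C(O)(C(F)(F)F)C(F)(F)F)ccc2ccccc12` gives 18 nM. Among the measured compounds shown here, the only measured step, a 110-fold higher number from compound 1 to compound 2 (2.05 log units; beyond the scatter), replaces the methyl on the carbonyl carbon with a larger aromatic group. Compound 3 `N#Cc1cccc(C(=O)Nc2c(C(O)(C(F)(F)F)C(F)(F)F)ccc3ccccc23)c1` differs from compound 2 in a single place: 3-cyanophenyl in place of 2-chlorophenyl on a carbonyl carbon. For the measured compounds named here, no measured step exchanges one aromatic group on the carbonyl carbon for another, so the measured step gives little guidance on the direction of this change; it shows only that this position responds strongly. Compound 3 is therefore expected to stay near compound 2 in this assay, with a 1.4-fold lower number from compound 2 to compound 3 (0.13 log units; within the scatter) as the expected step and a wide range. The estimate for compound 3 is 1500 nM, expected to fall between 300 nM and 8000 nM.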

Compound 3, half-maximal effective concentration: 12 nM
Beside the measured number, compound 3's estimate is 130-fold (2.10 log units) above it, outside the stated range (below it).
By their numbers in this assay, from the lowest: compounds 3 and 1 (each within the scatter of the next); then compound 2.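

Exchanging 2-chlorophenyl for 3-cyanophenyl on the carbonyl carbon gives a 170-fold lower number from compound 2 to compound 3 (2.23 log units; beyond the scatter) in this assay, so the high number of compound 2 does not hold for every aromatic group at this position. With a 1.5-fold lower number from compound 1 to compound 3 (0.18 log units; within the scatter), which lies within the scatter, the methyl and 3-cyanophenyl groups cannot be told apart in this assay, and a larger group at this position therefore need not raise the number. The compounds shown offer no evidence on why either step has its size. Since the nitrile and the chlorine also sit at different ring positions, the pair leaves open whether the identity of the group or its place decides the result; 3-chlorophenyl, 2-cyanophenyl and plain phenyl would separate the two. Going by these compounds, how an amine or a carboxylic acid on this ring would behave also remains open.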